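The source may hold more compounds than are shown below. What is called first, only, known or untested is meant among the compounds shown, and "the series" means these compounds.

Compound 1 `CNc1nc(N)nc2c1ncn2/C=C1/CC1(CO)CO` — in an ADME assay on CCRF-HSB-2 cells (Homo sapiens) for cytotoxicity, with a stated time of 7 days (on this read-out lower numbers stand for higher toxicity in this test and higher numbers for lower toxicity in this test), compound 1 gives > 20000 nM, which is a limit of the assay rather than a number.
Compound 2 `Nc1nc(OCC(F)(F)F)c2ncn(/C=C3/CC3(CO)CO)c2n1` — compound 2 gives > 20000 nM, again a limit of the assay.
Compound 3 `Nc1nc(NCc2ccccc2)c2ncn(/C=C3/CC3(CO)CO)c2n1` — compound 3 gives > 20000 nM, again a limit of the assay.

Compound 2 therefore stands where every measured compound of this set stands: at a limit, with no number below it. Among the measured compounds shown here, every value shown sits at the same point, (the limit of > 20000 nM in this assay, at which 3 of the 3 values shown sit), so no compound can be set above or below another.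

The step to be followed runs from compound 2 to compound 4 `CCCCCOc1nc(N)nc2c1ncn2/C=C1/CC1(CO)CO`, and the change is butyl in place of trifluoromethyl on a saturated chain carbon bound to an oxygen on an aromatic ring. Three steps among the measured compounds might bear on it. The nearest parallel is a step that the two limits leave unreadable from compound 1 to compound 2, where the same position on the core is altered; a step that the two limits leave unreadable from compound 1 to compound 3 and a step that the two limits leave unreadable from compound 2 to compound 3 also concern the same position. None of them gives a readable size, since both ends of each sit at the limit.

With every value at the limit, compound 4 is expected to remain there as well, and the estimated step that the limit leaves unreadable from compound 2 to compound 4 is not expected to exceed the scatter. Compound 4 is estimated at 30000 nM, with a range from 10000 nM to 100000 nM.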

Compound 4, half-maximal cytotoxic concentration: > 20000 nM
Compound 4: a limit, no number; the forecaster's own chance of this, stated with the estimate: 85%; the middle value lies beyond the limit too.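

In this assay compound 4 gives > 20000 nM, a limit of the assay and not a number. Its steps from compound 1, compound 2 and compound 3 cannot be read. The compounds shown leave open how far each lies past that limit, and whether any change on the shared core would yield a readable number: the limit of > 20000 nM in this assay, at which 4 of the 4 values shown sit.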